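A few compounds are considered here, and "the series" means these few. Any claim that something is new, unique, unknown or untested is made for them only; others in the source may bear on it.

Compounds 1 and 2 share one core. In a functional assay on SW-620 cells (Homo sapiens) for cytotoxicity, read by MTT assay, with a stated time of 3 days (a higher number here means that more compound is needed for the effect, a lower number that less compound is needed), compound 1 `O=C1/C(=C/c2ccccc2Cl)c2ccccc2N1c1c(Cl)cccc1Cl` gives 15 ug/mL. Compound 2 `O=C1/C(=C/c2cc3ccccc3nc2Cl)c2ccccc2N1c1c(Cl)cccc1Cl` gives 25 ug/mL in this assay, a number that cannot be told apart from that of compound 1, since the gap between them lies within the scatter. Compound 3 `Cc1ccc2nc(Cl)c(/C=C3/C(=O)N(c4c(Cl)cccc4Cl)c4ccccc43)cc2c1` differs from compound 2 by methyl in place of hydrogen on an aromatic carbon. Among the measured compounds shown here, no step between measured compounds shows what such a change does here, so the expected step is none beyond the scatter, in either direction. Compound 3 is thus expected to give 22 ug/mL in this assay, with a range from 9 ug/mL to 55 ug/mL. The expected change is a 1.1-fold lower number from compound 2 to compound 3 (0.06 log units; within the scatter).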

Compound 3, concentration for half-maximal effect: 40 ug/mL
Estimate against measurement, compound 3: 1.8-fold (0.26 log units) below; the measured number falls inside the stated range.
By their numbers in this assay, from the lowest: compounds 1, 2 and 3 (each within the scatter of the next, the first and the last beyond it).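

Among the compounds shown here, the step of a 1.6-fold higher number from compound 2 to compound 3 (0.20 log units; within the scatter) in this assay is the first single change that can be read. It shows that methyl in place of hydrogen on this aromatic carbon, meta to a fused ring and para to a fused ring, opens no gap beyond the scatter. No measurement shown here explains this result.

What the compounds shown leave open is whether a group other than methyl at this carbon, such as an amine, a carboxylic acid or a longer chain, would move the number beyond the scatter.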